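Working notes on a bile acid receptor agonist series

This account rests on a few compounds, and the source may have more. Where it says the series, first, only, none or still open, it means among the compounds named here.

Within the data shown here, compound 1 `CC(C)c1onc(-c2c(Cl)cccc2Cl)c1COc1ccc(N(C)Cc2ccc(C(=O)NS(C)(=O)=O)cc2)c(C(F)(F)F)n1` and compound 2 `CC(C)c1onc(-c2c(Cl)cccc2Cl)c1COc1cnc(N(C)Cc2ccc(C(=O)O)cc2)c(Cl)c1` share the same core and differ in several places at once, so no single-point step between them is available. In a functional assay on HEK293 cells for agonist activity at Bile acid receptor (Homo sapiens), read by a luciferase reporter (on this read-out higher numbers stand for larger maximal responses and lower numbers for smaller maximal responses), compound 1 gives 67%. In this assay compound 2 gives 51%. On the two numbers in hand compound 2 stands lowest; the nearest value, that of compound 1, is higher by a gap beyond the usual scatter of this read-out. Since the two structures differ in more than one place, that gap cannot be tied to any one change.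

Compound 3 `CC(C)c1onc(-c2c(Cl)cccc2Cl)c1COc1cnc(N(C)Cc2cccc(C(=O)O)c2)c(Cl)c1` has not yet been measured. It is the analogue of compound 2 with the following difference: 3-carboxyphenyl in place of 4-carboxyphenyl on a saturated chain carbon bound to a nitrogen on an aromatic ring. The two compounds contain the same atoms, joined differently, so nothing is added or taken away. Among the measured compounds shown here, no step of this kind has been measured, and the expectation rests only on the closeness of the two structures. The expected step is a number 6 percentage points lower from compound 2 to compound 3 (within the scatter), small and possibly within the scatter, with a slight fall judged somewhat more likely than a rise. Compound 3 is therefore estimated at 45%, in the range 25% to 65%.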

Compound 3, largest response reached (reported as efficacy), in percent of the reference or control that the assay uses: 54%
Compound 3: the middle estimate sits 9 percentage points below what was measured, and the stated range covers the measured number.
By their numbers in this assay, from the lowest: compounds 2 and 3 (each within the scatter of the next); then compound 1.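

Among these compounds, the change from 4-carboxyphenyl to 3-carboxyphenyl, on a saturated chain carbon bound to a nitrogen on an aromatic ring, is the first single-place comparison, and in this assay it gives a number 3 percentage points higher from compound 2 to compound 3 (within the scatter). The maximal response therefore does not separate these two arrangements of the same atoms at this position, so the carboxyphenyl group need not be attached as in compound 2 for the response to stay within the scatter of that compound. No supporting measurement bears on this result, and the data offer no explanation for it.

On these data alone, it remains open whether this lack of separation holds on other versions of the shared core, such as the core of compound 1, and whether it would extend to the acyl sulfonamide that compound 1 carries in place of the carboxylic acid. Also open, as far as these compounds go, are the effects of a tetrazole in place of the carboxylic acid, or of a longer chain between the nitrogen and the carboxyphenyl ring, on the maximal response in this assay.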